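Piperidin-1-yl for the arylamino group: compound 2 to compound 3

This account rests on a few compounds, and the source may have more. Where it says the series, first, only, none or still open, it means among the compounds named here.

In a functional assay on HeLa cells (Homo sapiens) for inhibition, read by sulforhodamine B assay (on this read-out lower numbers stand for stronger inhibition and higher numbers for weaker inhibition), compound 1 `O=C1C(Nc2ccccc2F)=CC(=O)c2c1nc1n2[C@H]2OC[C@@H](O)[C@H]2OC1` gives 9820 nM and compound 2 `Cc1ccc(NC2=CC(=O)c3c(nc4n3[C@H]3OC[C@@H](O)[C@H]3OC4)C2=O)cc1` gives 6590 nM. These two values lie within the scatter of each other, so compound 2 stands level with compound 1. Within the data shown here, the only measured step is a 1.5-fold lower number from compound 1 to compound 2 (0.17 log units; within the scatter), with 4-methylphenyl in place of 2-fluorophenyl on an amine nitrogen. Compound 3 `O=C1C(N2CCCCC2)=CC(=O)c2c1nc1n2[C@H]2OC[C@@H](O)[C@H]2OC1` carries piperidin-1-yl in place of (4-methylphenyl)amino on a double-bonded ring carbon. Among the measured compounds shown here, the measured step exchanges one aryl group for another on the amine nitrogen, and no measured compound lacks that amine hydrogen, so the evidence for this larger change is thin. In this assay, the expected outcome is a 1.2-fold higher number from compound 2 to compound 3 (0.08 log units; within the scatter), which means no shift beyond the scatter, with wide uncertainty in either direction. The estimate for compound 3 is 8000 nM, with an expected range of 2500 nM to 25000 nM.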

Compound 3, half-maximal inhibitory concentration: > 16000 nM
Compound 3 was reported as a limit; the forecaster's own chance of this, stated with the estimate: 15%; middle value at least 2.0-fold (0.30 log units) away from the limit.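

In this assay compound 3 stands as a limit and not as a number: the limit of > 16000 nM in this assay, at which 1 of the 3 values shown sits. The earlier aryl exchange on the amine nitrogen, a 1.5-fold lower number from compound 1 to compound 2 (0.17 log units; within the scatter), showed no shift beyond the scatter, whereas piperidin-1-yl in place of (4-methylphenyl)amino on the double-bonded ring carbon gives an at least 2.4-fold higher number from compound 2 to compound 3 (0.38 log units; beyond the scatter), so this position does respond when the whole arylamino group is replaced. The second reading, an at least 1.6-fold higher number from compound 1 to compound 3 (0.21 log units; that floor lies within the scatter), has a floor that stays within the scatter, so on its own it does not set compound 3 apart from compound 1.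

Among the compounds shown, the amine hydrogen and the aromatic ring leave together, so which of the two carries the difference stays open. Cyclohexylamino on the same carbon would keep the amine hydrogen without the aromatic ring, and methyl(phenyl)amino would keep the aromatic ring without the amine hydrogen.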